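From 3-chloro-4-fluorobenzyl to 3,3-dimethylbutyl: compound 3

The compounds below may be only part of what the source reports. "The series", "measured", "known", "first", "only" and "open" are said of these compounds alone.

Compound 1 `CCOc1cccc2c1S(=O)(=O)N=C2C1=C(O)[C@H](C(C)(C)C)N(CCC(C)(C)C)C1=O`: > 33000 nM, a limit
Compound 2 `CC(C)(C)[C@H]1C(O)=C(C2=NS(=O)(=O)c3c(OCC(N)=O)cccc32)C(=O)N1Cc1ccc(F)c(Cl)c1`: > 33000 nM, a limit
Compound 3 `CC(C)(C)CCN1C(=O)C(C2=NS(=O)(=O)c3c(OCC(N)=O)cccc32)=C(O)[C@@H]1C(C)(C)C`: not yet measured

In an ADME assay on Huh-7 cells (Homo sapiens) for cytotoxicity, with a stated time of 72 h (a lower number here means that less compound is tolerated, a higher number that more compound is tolerated), compound 2 gives > 33000 nM, which is a limit and not a number. Compound 2 therefore stands at the limit of > 33000 nM in this assay, at which 2 of the 2 values shown sit.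

Compound 3 differs from compound 2 in one place: neopentyl in place of 3-chloro-4-fluorophenyl on a saturated chain carbon bound to an amide-type nitrogen in a ring. This puts neopentyl in place of 3-chloro-4-fluorophenyl on a saturated chain carbon bound to an amide-type nitrogen in a ring. Cut one bond further out, the same difference reads 3-chloro-4-fluorobenzyl to 3,3-dimethylbutyl.

For the measured compounds named here, no measured step is available to size this change. Compound 1 also carries the 3,3-dimethylbutyl group and gives > 33000 nM, again a limit. On that basis, no step beyond the scatter is expected in this assay. The expected step is a number no higher from compound 2 to compound 3 (the limit leaves the size open). Compound 3 is expected at 33000 nM, with an estimated range of 15000 nM to 60000 nM.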

Compound 3, half-maximal cytotoxic concentration: > 33000 nM
Compound 3: only a limit was reported (the forecaster's own chance of this, stated with the estimate: 85%); the middle value lies on the limit itself.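

In this assay no new step can be read: the steps from compound 2 to compound 3 and from compound 1 to compound 3 join limits, not numbers, so their size stays unreadable. The values of compound 1, compound 2 and compound 3 coincide: the limit of > 33000 nM in this assay, at which 3 of the 3 values shown sit.

The compounds shown leave open where the half-maximal cytotoxic concentration of each lies, and whether either change shifts it.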